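Swapping 4-aminophenyl for thiophen-2-yl on the shared core

The source may report more compounds than this note shows. Statements on the series, on what has been measured and on what is new or still open speak of the compounds shown alone.

In a functional assay on NCI-H460 cells (Homo sapiens) for antiproliferative activity, read by MTT assay, with a stated time of 48 h (a higher number here means a weaker inhibitor, a lower number a stronger inhibitor), compound 3 (`COc1cc(-c2cccc3nc(-c4ccc(N)cc4)oc23)cc(OC)c1OC`) gives 310 nM and so stands lowest of the numbers shown. Compound 1 (`COc1cc(-c2cccc3nc(-c4cccc(F)c4)oc23)cc(OC)c1OC`), with 3-fluorophenyl, sits higher (3300 nM). For compound 2 (`COc1cc(-c2cccc3nc(-c4ccc(Cl)cc4)oc23)cc(OC)c1OC`), with 4-chlorophenyl, the reading is only a limit of the assay (> 25000 nM). Compound 4 (`COc1cc(-c2cccc3nc(-c4cccs4)oc23)cc(OC)c1OC`) puts thiophen-2-yl in place of the 4-aminophenyl of compound 3 (thiophen-2-yl in place of 4-aminophenyl on an aromatic carbon). For the measured compounds named here, no thiophen-2-yl compound has been measured yet, so the nearest guide is the two large steps towards the amino group (an 11-fold lower number from compound 1 to compound 3 (1.03 log units; beyond the scatter) and an at least 80-fold lower number from compound 2 to compound 3 (1.90 log units; beyond the scatter)). Compound 4 lacks that amino group, so a sizeable move to a higher number in this assay is expected. The expected step is large (a 9.7-fold higher number from compound 3 to compound 4 (0.99 log units; beyond the scatter)). Compound 4 is estimated at 3000 nM (expected range 600 nM to 15000 nM).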

Compound 4, half-maximal inhibitory concentration: 1600 nM
Beside the measured number, compound 4's estimate is 1.9-fold (0.27 log units) above it, within the range that was stated.
By their numbers in this assay, from the lowest: compound 3; then compound 4; then compound 1. At a limit, above all of these: compound 2.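

The amino group is not the only route to a lower number at this position: thiophen-2-yl, with no hydrogen-bond donor, still improves on 3-fluorophenyl, with a 2.1-fold lower number from compound 1 to compound 4 (0.31 log units; beyond the scatter). Even so, 4-aminophenyl stays ahead, with a 5.2-fold higher number from compound 3 to compound 4 (0.71 log units; beyond the scatter). The gain over 4-chlorophenyl, an at least 15-fold lower number from compound 2 to compound 4 (1.19 log units; beyond the scatter), rests on a limit of the assay for compound 2: the limit of > 25000 nM in this assay, at which 1 of the 4 values shown sits.

Still open, as far as these compounds go, is how furan-2-yl or thiophen-3-yl would compare at this position in this assay, and whether 3-aminophenyl or 4-hydroxyphenyl would come close to compound 3.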